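A few compounds are considered here, and "the series" means these few. Any claim that something is new, unique, unknown or untested is made for them only; others in the source may bear on it.

Measured in a physicochemical assay for solubility, read by chemiluminescence, measured as kinetic solubility; on this read-out lower numbers stand for lower solubility and higher numbers for higher solubility:
- Compound 1 `COc1nn(C)c2nc(N)nc(NS(=O)(=O)c3cccc(Cl)c3Cl)c12` gives >= 649000 nM (a limit).
- Compound 2 `CCNc1nc(NS(=O)(=O)c2cccc(Cl)c2Cl)c2c(OC)nn(C)c2n1` gives 219000 nM.
- Compound 3 `COc1nn(C)c2nc(NC(C)C)nc(NS(=O)(=O)c3cccc(Cl)c3Cl)c12` gives >= 551000 nM (a limit).

Compound 3 thus stands at >= 551000 nM, which is a limit and not a number. The change from compound 3 to compound 4 `COc1nn(C)c2nc(NC3COC3)nc(NS(=O)(=O)c3cccc(Cl)c3Cl)c12` is oxetan-3-yl in place of isopropyl on a nitrogen on an aromatic ring. Three measured steps alter the group on that nitrogen. Two run in opposite directions: an at least 2.9-fold lower number from compound 1 to compound 2 (0.47 log units; beyond the scatter), then an at least 2.5-fold higher number from compound 2 to compound 3 (0.40 log units; beyond the scatter). The third is a step that the two limits leave unreadable from compound 1 to compound 3. None of them introduces oxetan-3-yl, so only a modest expectation is justified, with nothing beyond the scatter: an at least 1.0-fold lower number from compound 3 to compound 4 (0.02 log units; that floor lies within the scatter). For compound 4 the estimated value is 520000 nM, with an expected range of 250000 nM to 700000 nM.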

Compound 4, solubility: >= 712000 nM
Compound 4 was reported as a limit; the forecaster's own chance of this, stated with the estimate: 65%; middle value at least 1.3-fold (0.13 log units) away from the limit.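

In this assay compound 4 gives >= 712000 nM, which is a limit and not a number. Oxetan-3-yl in place of ethyl on this nitrogen gives an at least 3.2-fold higher number from compound 2 to compound 4 (0.51 log units; beyond the scatter), so the first group with a ring here also stands clear of the ethyl compound. The steps from compound 1 and from compound 3 to compound 4 cannot be read, so hydrogen, isopropyl and oxetan-3-yl cannot be put in order. From the compounds shown here alone, what cyclobutyl, a four-membered ring without the oxygen, would give on this nitrogen stays open, and so does whether the oxygen matters at all.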